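Moving the Chlorine on the Phenyl Ring of Compound 3

A few compounds are considered here, and "the series" means these few. Any claim that something is new, unique, unknown or untested is made for them only; others in the source may bear on it.

Of the compounds shown here, three that share one core have been measured in an assay for inhibition of Intestinal-type alkaline phosphatase (Homo sapiens), read by spectrophotometry, with stated times of 10 min and 20 min; a higher number here means a weaker inhibitor, a lower number a stronger inhibitor. Compound 1 `COc1ccc(/C=C2\NS(=O)(=O)c3ccccc3C2=O)cc1` gives 1530 nM, compound 2 `O=C1/C(=C/c2ccccc2Br)NS(=O)(=O)c2ccccc21` gives 7430 nM, and compound 3 `O=C1/C(=C/c2cccc(Cl)c2)NS(=O)(=O)c2ccccc21` gives 3770 nM. Compound 3 thus has the second highest of the three numbers: its nearest neighbour is compound 2, and compound 1 sits further off, with a gap beyond the scatter. Among the compounds with values here, the one measured step that changes the same part of the molecule is a 2.0-fold lower number from compound 2 to compound 3 (0.29 log units; within the scatter).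

Compound 4 `O=C1/C(=C/c2ccc(Cl)cc2)NS(=O)(=O)c2ccccc21` differs from compound 3 in that same part: 4-chlorophenyl in place of 3-chlorophenyl on a double-bonded chain carbon bound to a double-bonded ring carbon. Within the data shown here, no measured pair shows exactly this change. Among the measured compounds shown here, the only comparable step, from compound 2 to compound 3, stayed within the scatter, while compound 1, which carries a different group on the phenyl, shows the lowest number. On that basis a modest step toward a lower number is expected, a 1.5-fold lower number from compound 3 to compound 4 (0.18 log units; within the scatter), but one that may well stay within the scatter. Compound 4 is therefore estimated at 2500 nM in this assay, with a range from 900 nM to 7500 nM.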

Compound 4, half-maximal inhibitory concentration: 4350 nM
Compound 4: middle estimate off by 1.7-fold (0.24 log units), on the low side, and the stated range covers the measured number.
By their numbers in this assay, from the lowest: compound 1; then compounds 3, 4 and 2 (each within the scatter of the next).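

In this assay, 4-chlorophenyl in place of 3-chlorophenyl gives a 1.2-fold higher number from compound 3 to compound 4 (0.06 log units; within the scatter), and 4-chlorophenyl in place of 2-bromophenyl gives a 1.7-fold lower number from compound 2 to compound 4 (0.23 log units; within the scatter), so in these compounds neither moving the chlorine around the phenyl ring nor exchanging the halogen-bearing group separates the numbers. Chloro in place of methoxy on an aromatic carbon, by contrast, gives a 2.8-fold higher number from compound 1 to compound 4 (0.45 log units; beyond the scatter), the only one of these new steps that clears the scatter, so here changing the group itself counts for more than moving the chlorine. Nothing available explains either the flat result or this larger step.

Still open, going by these compounds, is whether an amine or a carboxylic acid in place of the chloro on an aromatic carbon would give a larger step than methoxy does. Also open, on these data alone, is whether 4-bromophenyl would stay within the scatter of compound 4.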